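Chain length step in the anilide series

This account rests on a few compounds, and the source may have more. Where it says the series, first, only, none or still open, it means among the compounds named here.

Measured so far:
- compound 1, `CCCCCCc1nc(N)n(CC(=O)Nc2ccccc2)c1-c1ccccc1Br`: 8600 nM
- compound 2, `CCCCCc1nc(N)n(CC(=O)Nc2ccc(C)cc2)c1-c1ccccc1Br`: 5600 nM

In a functional assay on MIA PaCa-2 cells (Homo sapiens) for antiproliferative activity, read by MTT assay, with a stated time of 48 h (on this read-out higher numbers stand for weaker inhibition and lower numbers for stronger inhibition), compound 1 gives 8600 nM and compound 2 gives 5600 nM. Compound 2 stands beside compound 1; the two values lie within the scatter of each other, so no separation between them is established. Among the measured compounds shown here, no step between measured compounds that differ in one place has been measured.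

Compound 3, `CCCCCCc1nc(N)n(CC(=O)Nc2ccc(C)cc2)c1-c1ccccc1Br`, is not yet measured. From compound 2 it differs by methyl in place of hydrogen on a saturated chain carbon, five bonds along the chain from an aromatic carbon. Compound 1 carries the same chain as compound 3 but lacks the methyl on the anilide ring, and the values of compound 1 and compound 2 show only a gap within the scatter. On this basis the step from compound 2 to compound 3 is expected to be small, a 1.2-fold higher number from compound 2 to compound 3 (0.06 log units; within the scatter), with no direction beyond the scatter. In this assay compound 3 is therefore estimated at 6500 nM, within a range from 3000 nM to 14000 nM.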

Compound 3, half-maximal inhibitory concentration: 6500 nM
For compound 3 middle estimate and measured number coincide at the digits printed, within the range that was stated.
By their numbers in this assay, from the lowest: compounds 2, 3 and 1 (each within the scatter of the next).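

In this assay, among the compounds shown here, methyl in place of hydrogen on a saturated chain carbon, five bonds along the chain from an aromatic carbon, gives a 1.2-fold higher number from compound 2 to compound 3 (0.06 log units; within the scatter), the first measured step at this position, and it does not separate the two compounds. Methyl in place of hydrogen on an aromatic carbon gives a 1.3-fold lower number from compound 1 to compound 3 (0.12 log units; within the scatter), so this second change, also measured here for the first time, shows no separation either. No measurement at hand bears on these two results.

Neither step establishes a direction for its change, and a gap beyond the scatter has yet to appear in this set. From the compounds shown here alone, whether a longer chain, or an amine or a carboxylic acid in place of the methyl on the aromatic carbon, would give such a gap stays open.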